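Sulfanyl substituent at the quaternary ring carbon: extension to methoxyethyl

A few compounds are considered here, and "the series" means these few. Any claim that something is new, unique, unknown or untested is made for them only; others in the source may bear on it.

Of the compounds shown here, three have been tested in a functional assay on the whole organism (Pleural cavity) for inhibition, with Rattus norvegicus as the target, at a dose of 25 mg/kg; on this read-out higher numbers stand for more inhibition at the one dose given (going by the name of the read-out) and lower numbers for less inhibition. Compound 1 `CC1(Sc2ccccc2)C(=O)N(c2ccccc2)c2ncccc21` gives 0%. Compound 2 `CSC1(C)C(=O)N(c2ccccc2)c2ncccc21` gives 53%, and compound 3 `CCC1(C)C(=O)N(c2ccccc2)c2ncccc21` gives 12%. Compound 3 thus stands second of the three measured values: it lies a number 12 percentage points higher from compound 1 to compound 3 (beyond the scatter), and a number 41 percentage points lower from compound 2 to compound 3 (beyond the scatter). The third step, a number 53 percentage points higher from compound 1 to compound 2 (beyond the scatter), shows that the group on the sulfur decides much of the outcome.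

Compound 4 `COCCSC1(C)C(=O)N(c2ccccc2)c2ncccc21` differs from compound 3 by (2-methoxyethyl)sulfanyl in place of ethyl on a saturated ring carbon. The step bearing most directly on it is a number 41 percentage points lower from compound 2 to compound 3 (beyond the scatter), which is reversed here in kind, though with a larger chain on the sulfur. The step of a number 53 percentage points higher from compound 1 to compound 2 (beyond the scatter) shows that a small sulfanyl group gives the high reading and a large one none. A sulfanyl group of intermediate size is therefore expected to restore part of the inhibition, and compound 4 is estimated at 30%, within 5% to 60%, which means an expected step of a number 18 percentage points higher from compound 3 to compound 4 (beyond the scatter).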

Compound 4, a percentage reported as inhibition, in the whole organism at one dose (the size of the read-out at that dose, not a potency): 23%
For compound 4 the middle estimate is 7 percentage points above the measured one; low and high end bracket the measured number.
By their numbers in this assay, from the lowest: compound 1; then compound 3; then compound 4; then compound 2.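

In this assay a longer chain on the sulfur retains part of the inhibition, placing the (2-methoxyethyl)sulfanyl group in an intermediate position among the groups at this saturated ring carbon (a number 11 percentage points higher from compound 3 to compound 4 (beyond the scatter); a number 23 percentage points higher from compound 1 to compound 4 (beyond the scatter)). Adding methoxymethyl to the methyl on the sulfur still costs a substantial part of the reading (a number 30 percentage points lower from compound 2 to compound 4 (beyond the scatter)), so the methylsulfanyl group remains the best of the four groups compared here. Nothing measured accounts for this order.

The compounds shown leave open whether the reading follows the length of the chain on the sulfur or the ether oxygen within it. A propyl, 2-hydroxyethyl or 2-aminoethyl chain on the sulfur would help separate these two possibilities.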